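Three Benzoate Esters and an Untested 3-Nitrophenyl Analogue

The compounds below may be only part of what the source reports. "The series", "measured", "known", "first", "only" and "open" are said of these compounds alone.

Compound 1 `CC1=CC[C@H]2[C@H](CC[C@]2(C)O)C(C)(C)[C@@H]1CC[C@H]1[C@]2(C)CC[C@H](OC(=O)c3ccccc3)C(C)(C)O[C@H]2CC[C@@]1(C)O`: 16100 nM
Compound 2 `CC1=CC[C@H]2[C@H](CC[C@]2(C)O)C(C)(C)[C@@H]1CC[C@H]1[C@]2(C)CC[C@H](OC(=O)c3ccc(F)cc3)C(C)(C)O[C@H]2CC[C@@]1(C)O`: 11300 nM
Compound 3 `CC1=CC[C@H]2[C@H](CC[C@]2(C)O)C(C)(C)[C@@H]1CC[C@H]1[C@]2(C)CC[C@H](OC(=O)c3ccc(Cl)c(Cl)c3)C(C)(C)O[C@H]2CC[C@@]1(C)O`: 8100 nM

All three values come from a functional assay on MDA-MB-231 cells (Homo sapiens) for antiproliferative activity, read by MTT assay, with a stated time of 72 h; a higher number here means a weaker inhibitor, a lower number a stronger inhibitor. Compound 3 stands at 8100 nM, but the numbers do not set it apart from the other two: the measured steps are a 2.0-fold lower number from compound 1 to compound 3 (0.30 log units; within the scatter) and a 1.4-fold lower number from compound 2 to compound 3 (0.14 log units; within the scatter).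

Compound 4 `CC1=CC[C@H]2[C@H](CC[C@]2(C)O)C(C)(C)[C@@H]1CC[C@H]1[C@]2(C)CC[C@H](OC(=O)c3cccc([N+](=O)[O-])c3)C(C)(C)O[C@H]2CC[C@@]1(C)O` keeps the shared core and differs in one place: 3-nitrophenyl in place of 3,4-dichlorophenyl on a carbonyl carbon. In words, this is 3-nitrophenyl in place of 3,4-dichlorophenyl on a carbonyl carbon.

Within the data shown here, the steps that bear on this change are the exchanges already measured at that same carbonyl carbon. Besides the two above, there is a 1.4-fold lower number from compound 1 to compound 2 (0.15 log units; within the scatter). Among the measured compounds shown here, none of the measured compounds carries the 3-nitrophenyl group, so the data offer no direct reading of it. Resting on these three small steps, no step beyond the scatter is expected in this assay, and no direction is favoured. The estimated step is a 1.2-fold higher number from compound 3 to compound 4 (0.09 log units; within the scatter). For compound 4 the expected value is 10000 nM, with an estimated range of 5000 nM to 20000 nM.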

Compound 4, half-maximal inhibitory concentration: 34700 nM
Compound 4: the middle estimate sits 3.5-fold (0.54 log units) below what was measured, and the stated range ends below it.
By their numbers in this assay, from the lowest: compounds 3, 2 and 1 (each within the scatter of the next); then compound 4.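

At this carbonyl carbon, the aromatic group of the ester can move the number in this assay beyond the scatter, which no exchange among the first three compounds had done: the 3-nitrophenyl ester gives a 4.3-fold higher number from compound 3 to compound 4 (0.63 log units; beyond the scatter) and also a 3.1-fold higher number from compound 2 to compound 4 (0.49 log units; beyond the scatter) while, against the unsubstituted benzoate, nitro in place of hydrogen gives a 2.2-fold higher number from compound 1 to compound 4 (0.33 log units; beyond the scatter) as well. The position is therefore not indifferent to what the ester carries, and the one clear move seen here runs towards weaker inhibition, with compound 4 the weakest of the four and compounds 1, 2 and 3 remaining within the scatter of their neighbours in the order. Nothing shown gives a measured reason for this shift.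

Going by these compounds, whether the rise belongs to the nitro group itself or to the loss of the halogens cannot be separated with a single nitro compound, and how an amine, a nitrile or a carboxylic acid on the same aromatic ring would read remains open. Also open, on these data alone, is whether a longer alkyl chain in place of the aromatic ring on this carbonyl carbon would keep the number near those of the halogenated esters.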